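Methylamino on the carbonyl carbon of compound 4

This account rests on a few compounds, and the source may have more. Where it says the series, first, only, none or still open, it means among the compounds named here.

Measured in a functional assay on the whole organism with Mus musculus as the target; a higher number here means that more compound is needed for the effect, a lower number that less compound is needed:
- compound 1 `O=C1CCN(c2ccc(-c3ccc(Cl)cc3Cl)nn2)CC1`: 7.3 mg/kg
- compound 2 `CCCC(=O)OC1CCN(c2ccc(-c3ccccc3Cl)nn2)CC1`: 39 mg/kg
- compound 3 `O=C(OC1CCN(c2ccc(-c3ccccc3Cl)nn2)CC1)C1CC1`: 92 mg/kg

Compound 3 has the highest number of the three, with compound 2 nearest and compound 1 furthest. Compound 4 `CNC(=O)OC1CCN(c2ccc(-c3ccccc3Cl)nn2)CC1` carries methylamino in place of cyclopropyl on a carbonyl carbon. For the measured compounds named here, the only measured step at this place, cyclopropyl in place of propyl, is a 2.4-fold higher number from compound 2 to compound 3 (0.37 log units; beyond the scatter). Going by the values given here, no measured compound carries methylamino, so the direction is untested. A modest change in this assay is expected, more likely towards a lower number. The expected step is a 2.0-fold lower number from compound 3 to compound 4 (0.31 log units; beyond the scatter). For compound 4 the estimate is 45 mg/kg, with an estimated range of 15 mg/kg to 130 mg/kg.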

Compound 4, dose for half-maximal effect: 13 mg/kg
For compound 4 the middle estimate is 3.5-fold (0.54 log units) above the measured one; the measured number lies below the stated range.
By their numbers in this assay, from the lowest: compounds 1 and 4 (each within the scatter of the next); then compound 2; then compound 3.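

In this assay methylamino in place of cyclopropyl on this carbonyl carbon gives a 7.1-fold lower number from compound 3 to compound 4 (0.85 log units; beyond the scatter) and methylamino in place of propyl gives a 3.0-fold lower number from compound 2 to compound 4 (0.48 log units; beyond the scatter) at the same place. The position therefore responds to more than a change of carbon group: among the three groups compared here, methylamino gives the lowest number, then propyl, then cyclopropyl. No measurement at hand explains this result. From the compounds shown here alone, whether the methylamino result extends to other amino groups remains open. Ethylamino or dimethylamino on the same carbonyl carbon would test this.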